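The source may report more compounds than this note shows. Statements on the series, on what has been measured and on what is new or still open speak of the compounds shown alone.

Compound 3, with the structure `S=C(SCc1cn(Cc2ccc(Cl)c(Cl)c2)nn1)N1CCNCC1`, has no number of its own in a functional assay on PC-3 cells (Homo sapiens) for inhibition, read by MTT assay, with a stated time of 72 h; a lower number here means a stronger inhibitor, a higher number a weaker inhibitor: the entry for compound 3 reads "not determined" (no result reported). The same holds for its close relative compound 2, with the structure `S=C(SCc1cn(Cc2ccccc2Cl)nn1)N1CCNCC1`, whose entry in this assay is "not determined" (no result reported). Among the measured compounds shown here, the only related compound with a result is compound 1, with the structure `O=C(OCc1ccccc1)N1CCN(C(=S)SCc2cn(Cc3ccc(Cl)cc3)nn2)CC1`. In this assay compound 1 gives > 128000 nM, and that figure is a limit of the measurement rather than a number. So compound 3 stands among three entries of which none is a plain number: one is the limit of > 128000 nM in this assay, at which 1 of the 3 values shown sits, and one, like its own, is empty.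

Compound 4, with the structure `S=C(SCc1cn(Cc2ccc(Cl)cc2)nn1)N1CCNCC1`, differs from compound 3 in one place: hydrogen in place of chloro on an aromatic carbon. For the measured compounds named here, no measured pair in this set shows what such a change does in this assay, so there is no step to lean on. Without a number for compound 3 the direction cannot be anchored, and no shift beyond the usual scatter is assumed. On that thin footing compound 4 is expected to give about 50000 nM in this assay, somewhere between 8000 nM and 200000 nM, with a real chance that only a limit is reported, as for compound 1.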

Compound 4, half-maximal inhibitory concentration: > 128000 nM
Compound 4 ended at the assay's limit; the forecaster's own chance of this, stated with the estimate: 45%; middle value at least 2.5-fold (0.40 log units) from the limit.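

In this assay compound 4 gives > 128000 nM, which is a limit of the assay and not a number. Compound 1 also sits at a limit, so no step between compound 1 and compound 4 can be read: the limit of > 128000 nM in this assay, at which 2 of the 4 values shown sit.

The compounds shown leave open whether the 3,4-dichlorophenyl group of compound 3 would give a different result from the 4-chlorophenyl group of compound 4 in this assay.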